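Swapping the Sulfonyl Aryl Group Toward a Dimethoxyphenyl

A few compounds are considered here, and "the series" means these few. Any claim that something is new, unique, unknown or untested is made for them only; others in the source may bear on it.

Compound 2 `COc1cc(N)c(Cl)cc1C(=O)CCC1CCN(CCNS(=O)(=O)c2ccc(NC(C)=O)cc2)CC1` carries a 4-acetamidophenyl on its sulfonyl sulfur. In an assay on HEK293 cells for displacement of a labelled ligand from 5-hydroxytryptamine receptor 6 (Homo sapiens), with a stated time of 60 min, tested at 0.01 uM, in the presence of a further agent that is not named here (on this read-out lower numbers stand for a weaker effect and higher numbers for a stronger effect at the one concentration tested), compound 2 gives 7%, the lowest of the two numbers available. Its nearest neighbour is compound 1 `COc1ccc(S(=O)(=O)NCCN2CCC(CCC(=O)c3cc(Cl)c(N)cc3OC)CC2)cc1Cl`, which in this assay gives 20%; the step of a number 13 percentage points lower from compound 1 to compound 2 (beyond the scatter) is modest but beyond the scatter. A third compound, compound 3 `COc1cc(N)c(Cl)cc1C(=O)CCC1CCN(CCNS(=O)(=O)c2ccc3c(c2)NC(=O)CO3)CC1`, was reported in this assay only as "not active" (no number reported), without a number.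

Compound 4 `COc1ccc(S(=O)(=O)NCCN2CCC(CCC(=O)c3cc(Cl)c(N)cc3OC)CC2)cc1OC` differs from compound 2 in one place: 3,4-dimethoxyphenyl in place of 4-acetamidophenyl on a sulfonyl sulfur. Among the compounds with values here, the only measured step that bears on this change is a number 13 percentage points lower from compound 1 to compound 2 (beyond the scatter), which exchanged a 3-chloro-4-methoxyphenyl for the 4-acetamidophenyl; compound 4 goes the other way, to a 3,4-dimethoxyphenyl that resembles the group of compound 1. Within the data shown here, because compound 1 gives 20% and compound 2 only 7%, a modest rise back toward the number of compound 1 is expected, though no compound with this exact group has been measured, so the expectation is uncertain. The estimated step is a number 8 percentage points higher from compound 2 to compound 4 (within the scatter). Compound 4 is therefore expected to give 15% in this assay, with a range from 0% to 35%.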

Compound 4, a percentage reported as inhibition, at one concentration (the size of the read-out at that concentration, not a potency): 3%
Compound 4: the middle estimate sits 12 percentage points above what was measured, and the stated range covers the measured number.
By their numbers in this assay, from the lowest: compounds 4 and 2 (each within the scatter of the next); then compound 1.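

In this assay, exchanging the 4-acetamidophenyl on the sulfonyl sulfur for a 3,4-dimethoxyphenyl gives a number 4 percentage points lower from compound 2 to compound 4 (within the scatter), so this read-out does not separate these two groups, even though they differ in their counts of hydrogen-bond donors and acceptors. Within the data shown here, the more informative comparison is the single change of methoxy in place of chloro on an aromatic carbon, which gives a number 17 percentage points lower from compound 1 to compound 4 (beyond the scatter) and shows that the close resemblance of the two sulfonyl aryl groups does not carry a similar number with it: of these three compounds, only compound 1, with the chloro, stands apart. Nothing available here accounts for this difference between chloro and methoxy.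

Going by these compounds, it remains open whether the higher number of compound 1 is specific to chloro, or whether another group on that aromatic carbon, such as fluoro, bromo, methyl or trifluoromethyl, would match or exceed it. Also open, on these data alone, is how an amine or a carboxylic acid on the sulfonyl aryl ring would read, and whether these small differences at a single concentration would hold up in a full potency measurement.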